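Quinone series: tert-butyl in place of methyl

A few compounds are considered here, and "the series" means these few. Any claim that something is new, unique, unknown or untested is made for them only; others in the source may bear on it.

Measured compounds in a functional assay on A2780 cells (Homo sapiens) for inhibition, read by sulforhodamine B assay, with a stated time of 72 h; on this read-out higher numbers stand for weaker inhibition and lower numbers for stronger inhibition:
compound 1 `CNC1=C(C)C(=O)C=C(C(C)C)C1=O`: 14000 nM
compound 2 `CC1=CC(=O)C(N(C)C)=CC1=O`: 6200 nM
compound 3 `CC1=CC(=O)C(C(C)(C)C)=CC1=O`: 7500 nM

Compound 3 stands second highest of the three numbers; its nearest neighbour is compound 2, a step within the scatter, and its furthest is compound 1, also within the scatter. Among the measured compounds shown here, the only single-point step recorded is a 1.2-fold higher number from compound 2 to compound 3 (0.08 log units; within the scatter).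

Compound 4 `CC(C)(C)C1=CC(=O)C(C(C)(C)C)=CC1=O` differs from compound 3 as follows: tert-butyl in place of methyl on a double-bonded ring carbon. For the measured compounds named here, no measured step exchanges methyl for tert-butyl, so the expectation rests on the one step known, which was within the scatter. The step of a 1.1-fold lower number from compound 3 to compound 4 (0.03 log units; within the scatter) is therefore expected to stay within the scatter. Compound 4 is estimated at 7000 nM, with a range from 3000 nM to 18000 nM.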

Compound 4, half-maximal inhibitory concentration: 34000 nM
Estimate against measurement, compound 4: 4.9-fold (0.69 log units) below; measured number outside the range, above it.
By their numbers in this assay, from the lowest: compounds 2, 3 and 1 (each within the scatter of the next, the first and the last beyond it); then compound 4.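

Tert-butyl in place of methyl on this double-bonded ring carbon is the first single change in the series to move the number beyond the scatter in this assay (a 4.5-fold higher number from compound 3 to compound 4 (0.66 log units; beyond the scatter)), and it weakens inhibition. The earlier single change, tert-butyl in place of dimethylamino (a 1.2-fold higher number from compound 2 to compound 3 (0.08 log units; within the scatter)), stayed within the scatter, so this ring carbon does not tolerate every exchange of a group for tert-butyl. No evidence at hand explains the loss.

Going by these compounds, whether ethyl at this carbon would stay near compound 3 or fall nearer compound 4 remains open. So does the outcome with a primary amine or a carboxylic acid there.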